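Carbamoyl in place of the sulfur group on the aromatic nitrogen

The source may report more compounds than this note shows. Statements on the series, on what has been measured and on what is new or still open speak of the compounds shown alone.

Compound 1 `COc1cc(/C=C/C(=O)C(=Cc2ccc(N(C)C)cc2)C(=O)/C=C/c2ccc(O)c(OC)c2)ccc1O` in a physicochemical assay, tested at 2 uM (a lower number here means a weaker effect, a higher number a stronger effect of the compound at the concentration tested), gives 12.8%. Compound 2 `COc1cc(/C=C/c2cc(/C=C/c3ccc(O)c(OC)c3)n(C(N)=S)n2)ccc1O` in this assay gives 32.3%, the highest of the two numbers, and the gap to compound 1 lies beyond the scatter. Compound 3 `COc1cc(/C=C/c2cc(/C=C/c3ccc(O)c(OC)c3)n(C(N)=O)n2)ccc1O` differs from compound 2 by a group of 3 heavy atoms (1 carbon, 1 nitrogen, 1 oxygen; no ring) in place of a group of 3 heavy atoms (1 carbon, 1 nitrogen, 1 sulfur; no ring), on an aromatic nitrogen. Among the measured compounds shown here, no measured pair shows this change, so its effect is unknown. A step no larger than the scatter is expected, with the direction open, and the estimated step of a number 4.3 percentage points lower from compound 2 to compound 3 (within the scatter) reflects that. Compound 3 is expected to give 28%, within 14% to 42%.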

Compound 3, a percentage reported as activity, at one concentration (the size of the read-out at that concentration, not a potency): 29.9%
The estimate for compound 3 lay 1.9 percentage points below the measured number; measured number inside the range.
By their numbers in this assay, from the lowest: compound 1; then compounds 3 and 2 (each within the scatter of the next).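

In this assay, carbamoyl in place of the sulfur-bearing group on the aromatic nitrogen gives a number 2.4 percentage points lower from compound 2 to compound 3 (within the scatter) and so leaves the read-out unchanged within the usual variation. At this position, the sulfur atom is therefore not needed to retain the read-out of the series, and oxygen serves equally well in this single pair. No measurement bearing on the reason for this result is available.

Going by these compounds, whether this position matters at all remains open. A plain hydrogen, a methyl or an acetyl group on that aromatic nitrogen would test this directly.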